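A few compounds are considered here, and "the series" means these few. Any claim that something is new, unique, unknown or untested is made for them only; others in the source may bear on it.

The account begins with compound 1 `O=C(NO)c1ccc(-c2cn([C@H]3C[C@@H](C(=O)O)N(CCCc4ccccc4)C3)nn2)cc1` and compound 2 `O=C(NO)c1ccc(-c2cn([C@@H]3C[C@@H](CO)N(CCCc4ccccc4)C3)nn2)cc1`, two compounds built on the same core and carrying a 3-phenylpropyl group on the five-membered non-aromatic ring. In an assay on Sf9 cells for inhibition of histone deacetylase 11 (Homo sapiens), read by fluorescence, tested at 0.5 uM (on this read-out lower numbers stand for less inhibition and higher numbers for more inhibition at the one concentration tested (going by the name of the read-out)), compound 1 gives 14%. In this assay compound 2 gives 14%, level with compound 1 at the digits shown, so the two show no difference beyond the usual scatter. Compound 3 `O=C(NO)c1ccc(-c2cn([C@@H]3C[C@@H](C(=O)O)N(CCCc4ccccc4)C3)nn2)cc1` has not yet been measured. Relative to compound 2 the change is carboxy in place of hydroxymethyl on a saturated ring carbon; compound 3 is thus the carboxy counterpart of compound 2 and a stereoisomer of compound 1. For the measured compounds named here, no step between measured compounds is available to set the size of this change. Since compound 1 with 14% and compound 2 with 14% sit level, a carboxy and a hydroxymethyl group have each appeared with the same low inhibition, and the expected step of a number 1 percentage points higher from compound 2 to compound 3 (within the scatter) is none beyond the scatter. Compound 3 is therefore estimated at 15%, with a range from 5% to 28%.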

Compound 3, a percentage reported as inhibition, at one concentration (the size of the read-out at that concentration, not a potency): 14%
Compound 3: the middle estimate sits 1 percentage points above what was measured; measured number inside the range.
By their numbers in this assay, from the lowest: compounds 1, 2 and 3 (each within the scatter of the next).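

For the compounds shown here, compound 3 supplies the first comparisons in which only one feature differs, which compounds 1 and 2 could not provide. In this assay, carboxy in place of hydroxymethyl on this saturated ring carbon, next to the ring nitrogen, gives no change at the digits printed from compound 2 to compound 3 (within the scatter), so at this configuration the exchange of these two groups is not seen in the read-out. Changing the stereocentre at a saturated ring carbon from S to R with the carboxy group in place gives no change at the digits printed from compound 1 to compound 3 (within the scatter), and this pair tests the stereocentre alone: the fact that compounds 1 and 3 differ only in the configuration as drawn.

Going by these compounds, whether an amine, a methyl ester or a primary amide on this carbon would read differently stays open, as does the effect of a shorter or longer chain in place of the 3-phenylpropyl group. All three compounds sit level at a single concentration in this assay, so these results give no potency and cannot show whether the two changes would separate at another concentration.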